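From 4-chlorophenyl to 3-bromophenyl, starting at a limit

The source may report more compounds than this note shows. Statements on the series, on what has been measured and on what is new or still open speak of the compounds shown alone.

All readings so far come from a functional assay on Raji cells (Homo sapiens) for cytotoxicity, with a stated time of 72 h (a higher number here means that more compound is needed for the effect, a lower number that less compound is needed), with compound 1 (`C=C[C@@](C)(/C=C/c1ccc(Nc2ccc(F)cc2)cc1)CCC=C(C)C`) and compound 2 (`C=C[C@@](C)(/C=C/c1ccc(-c2ccc(Cl)cc2)cc1)CCC=C(C)C`) as the measured pair. Compound 1 gives > 26000 nM, which is a limit and not a number. Compound 2 gives > 26000 nM, also a limit, so compound 2 has no number of its own. Both measured compounds sit at one point: the limit of > 26000 nM in this assay, at which 2 of the 2 values shown sit.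

Compound 3 (`C=C[C@@](C)(/C=C/c1ccc(-c2cccc(Br)c2)cc1)CCC=C(C)C`) carries 3-bromophenyl in place of 4-chlorophenyl on an aromatic carbon, para to a large group: 3-bromophenyl in place of 4-chlorophenyl on an aromatic carbon. Among the compounds with values here, the one measured step that bears on this change is a step that the two limits leave unreadable from compound 1 to compound 2. It also exchanges a group on an aromatic carbon, but it offers no size to carry over and no direction. No step beyond the scatter is therefore expected in this assay, and another reading at the limit is the likeliest outcome. This expectation rests on compound 2, whose limit is > 26000 nM. The expected change is a step that the limit leaves unreadable from compound 2 to compound 3. For compound 3 the estimated value is 30000 nM, with an expected range of 13000 nM to 60000 nM.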

Compound 3, half-maximal effective concentration: > 26000 nM
Compound 3: only a limit was reported; the forecaster's own chance of this, stated with the estimate: 70%; the middle value is on the limit's open side.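

Compound 3 gives > 26000 nM in this assay, which is a limit and not a number. No new step can be read from compound 3 to either compound 2 or compound 1. All three compounds sit at one point: the limit of > 26000 nM in this assay, at which 3 of the 3 values shown sit.

The compounds shown leave open what actual value each compound has and whether any of these exchanges on the aromatic carbon changes it.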